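Cytotoxicity of a Dihalogenated Analogue Predicted from Three Measurements

The compounds below may be only part of what the source reports. "The series", "measured", "known", "first", "only" and "open" are said of these compounds alone.

Compound 1 `Cc1cc(S(N)(=O)=O)ccc1NC(=O)COc1ccc(Cl)cc1C(O)c1ccccc1`: 33400 nM
Compound 2 `Cc1cc(S(N)(=O)=O)ccc1NC(=O)COc1ccc(Cl)cc1C(O)c1ccccc1Cl`: 32000 nM
Compound 3 `Cc1cc(S(N)(=O)=O)ccc1NC(=O)COc1ccc(Cl)cc1C(O)c1cccc(C)c1C`: 218000 nM

In an ADME assay on C8166 cells (Homo sapiens) for cytotoxicity, read by MTT assay (on this read-out higher numbers stand for lower toxicity in this test and lower numbers for higher toxicity in this test), compound 3 gives the highest number of the three, standing a 6.5-fold higher number from compound 1 to compound 3 (0.81 log units; beyond the scatter) and a 6.8-fold higher number from compound 2 to compound 3 (0.83 log units; beyond the scatter). Compound 4 `Cc1cc(S(N)(=O)=O)ccc1NC(=O)COc1ccc(Cl)cc1C(O)c1cc(Cl)cc(Br)c1` is the next step from compound 3; the change is 3-bromo-5-chlorophenyl in place of 2,3-dimethylphenyl on a saturated chain carbon bound to an aromatic carbon and an oxygen on a saturated carbon.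

Among the measured compounds shown here, two measured steps bear on it. Both earlier steps that introduced the 2,3-dimethylphenyl in place of a phenyl or 2-chlorophenyl raised the number modestly, as a 6.5-fold higher number from compound 1 to compound 3 (0.81 log units; beyond the scatter) and a 6.8-fold higher number from compound 2 to compound 3 (0.83 log units; beyond the scatter) show, while placing chloro in place of hydrogen gave a 1.0-fold lower number from compound 1 to compound 2 (0.02 log units; within the scatter). Compound 4 removes the 2,3-dimethylphenyl again and brings in a ring carrying two halogens, and the only halogenated ring measured so far, in compound 2, sat close to the plain phenyl of compound 1. For the measured compounds named here, the expectation is therefore that compound 4 returns partway toward those two compounds, a drop of roughly a 3.6-fold lower number from compound 3 to compound 4 (0.56 log units; beyond the scatter), with wide uncertainty because the two halogens together have no measured precedent here. Compound 4 is estimated at 60000 nM, within a range from 20000 nM to 250000 nM.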

Compound 4, half-maximal cytotoxic concentration: 22900 nM
The estimate for compound 4 lay 2.6-fold (0.42 log units) above the measured number; the measured number falls inside the stated range.
By their numbers in this assay, from the lowest: compounds 4, 2 and 1 (each within the scatter of the next); then compound 3.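

In this assay, replacing the 2,3-dimethylphenyl with the 3-bromo-5-chlorophenyl removes the whole gain seen with compound 3 (a 9.5-fold lower number from compound 3 to compound 4 (0.98 log units; beyond the scatter)), so that gain does not carry over to every ring with two substituents. Compound 4 cannot be told apart from the compound with the 2-chlorophenyl (a 1.4-fold lower number from compound 2 to compound 4 (0.15 log units; within the scatter)) or from the one with the plain phenyl (a 1.5-fold lower number from compound 1 to compound 4 (0.16 log units; within the scatter)), since both steps lie within the scatter. Across these four compounds, then, a ring with no halogen, with chlorine alone, or with both chlorine and bromine gives much the same reading at this position, and compound 3 is the one compound that goes against this pattern, though nothing measured here explains why its ring stands apart.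

Still open, as far as these compounds go, is whether the high number of compound 3 needs both methyl groups, which a 2-methylphenyl or a 3-methylphenyl at the same position would help to show. From the compounds shown here alone, it is also open how this position responds to a ring carrying something other than methyl or halogen, such as an amine or a carboxylic acid.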